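Trifluoromethoxyphenyl Replaces Chloromethoxyphenyl at the Bile Acid Receptor

A few compounds are considered here, and "the series" means these few. Any claim that something is new, unique, unknown or untested is made for them only; others in the source may bear on it.

Compound 1 `COC(=O)/C=C/c1cccc(N(Cc2ccc(/C=C/c3cccc(F)c3)cc2)C(=O)C(C)C)c1` gives 71 nM in an assay on isolated protein with Bile acid receptor (Homo sapiens) as the target; a lower number here means that less compound is needed, a higher number that more compound is needed for the effect.
Compound 2 `COC(=O)/C=C/c1cccc(N(Cc2ccc(-c3ccc(SC)cc3)cc2)C(=O)C(C)C)c1` gives 51 nM in this assay.
Compound 3 `COC(=O)/C=C/c1cccc(N(Cc2ccc(-c3cc(Cl)ccc3OC)cc2)C(=O)C(C)C)c1` gives 226 nM in this assay.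

Compound 3 stands highest of the three numbers: a 3.2-fold higher number from compound 1 to compound 3 (0.50 log units; beyond the scatter) and a 4.4-fold higher number from compound 2 to compound 3 (0.65 log units; beyond the scatter), both beyond the scatter. Compound 4 `COC(=O)/C=C/c1cccc(N(Cc2ccc(-c3ccc(OC(F)(F)F)cc3)cc2)C(=O)C(C)C)c1` arises from compound 3 by 4-(trifluoromethoxy)phenyl in place of 5-chloro-2-methoxyphenyl on an aromatic carbon. The step most relevant is a 4.4-fold higher number from compound 2 to compound 3 (0.65 log units; beyond the scatter), as compound 2 also carries a single-ring group with one substituent on the phenyl, like compound 4. Read in reverse, that step points to a lower number for compound 4, though the exact size is uncertain because compound 1 gives no direct step. Compound 4 is expected to give 70 nM, within 30 nM to 180 nM. The estimated step is a 3.2-fold lower number from compound 3 to compound 4 (0.51 log units; beyond the scatter).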

Compound 4, half-maximal effective concentration: 219 nM
For compound 4 the middle estimate is 3.1-fold (0.50 log units) below the measured one; the measured number lies above the stated range.
By their numbers in this assay, from the lowest: compounds 2 and 1 (each within the scatter of the next); then compounds 4 and 3 (each within the scatter of the next).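

In this assay, 4-(trifluoromethoxy)phenyl in place of 5-chloro-2-methoxyphenyl gives a 1.0-fold lower number from compound 3 to compound 4 (0.01 log units; within the scatter), so the two groups cannot be told apart at this position. A single substituent on the phenyl therefore does not by itself bring the number to that of compound 2: trifluoromethoxy in place of methylsulfanyl gives a 4.3-fold higher number from compound 2 to compound 4 (0.63 log units; beyond the scatter), and the change from the 2-(3-fluorophenyl)ethenyl group gives a 3.1-fold higher number from compound 1 to compound 4 (0.49 log units; beyond the scatter). No measurement at hand accounts for these steps.

The compounds shown leave open whether an amine or a carboxylic acid on that phenyl would stay close to compound 2, and whether ethylsulfanyl, a longer chain on the sulfur, would do the same.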